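Methyl on the piperidine ring: a small step expected

The compounds below may be only part of what the source reports. "The series", "measured", "known", "first", "only" and "open" are said of these compounds alone.

In a functional assay on MKN-45 cells (Homo sapiens) for inhibition, read by MTT assay, with a stated time of 72 h (a higher number here means a weaker inhibitor, a lower number a stronger inhibitor), compound 3 `COc1cc2c(Oc3ccc(NC(=O)c4nn(-c5ccccc5C(F)(F)F)c(=O)cc4C)cc3F)ccnc2cc1OCCCN1CCCCC1` gives 90 nM. Compound 2 `COc1cc2c(Oc3ccc(NC(=O)c4nn(-c5ccccc5C(F)(F)F)c(=O)cc4C)cc3F)ccnc2cc1OCCCN1CCCC1` gives 100 nM in this assay, and a 1.1-fold lower number from compound 2 to compound 3 (0.05 log units; within the scatter), so the two numbers cannot be told apart. Compound 1 `COc1cc2c(Oc3ccc(NC(=O)c4nn(-c5ccccc5C)c(=O)cc4C)cc3F)ccnc2cc1OCCCN1CCC(C)CC1` gives 1290 nM in this assay, a number beyond the scatter from compound 3; compound 1, however, differs from compound 3 in two places, with a methyl in place of the trifluoromethyl on the aryl as well as a methyl on the ring, so its gap cannot be assigned to either change alone.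

Compound 4 `COc1cc2c(Oc3ccc(NC(=O)c4nn(-c5ccccc5C(F)(F)F)c(=O)cc4C)cc3F)ccnc2cc1OCCCN1CCC(C)CC1` differs from compound 3 by methyl in place of hydrogen on a saturated ring carbon. Going by the values given here, no measured pair isolates this change. Among the compounds with values here, the only step at this end of the molecule, a 1.1-fold lower number from compound 2 to compound 3 (0.05 log units; within the scatter), was within the scatter, which suggests that alterations of the saturated ring there move the number little. Compound 4 is therefore expected to give about 100 nM in this assay, estimated between 45 nM and 250 nM, an expected step of a 1.1-fold higher number from compound 3 to compound 4 (0.05 log units; within the scatter).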

Compound 4, half-maximal inhibitory concentration: 60 nM
For compound 4 the middle estimate is 1.7-fold (0.22 log units) above the measured one, and the stated range covers the measured number.
By their numbers in this assay, from the lowest: compounds 4, 3 and 2 (each within the scatter of the next); then compound 1.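

In this assay, the methyl on the saturated ring leaves the number within the scatter, with a 1.5-fold lower number from compound 3 to compound 4 (0.18 log units; within the scatter), and 4-methylpiperidin-1-yl also stays within the scatter of pyrrolidin-1-yl, with a 1.7-fold lower number from compound 2 to compound 4 (0.22 log units; within the scatter). Compound 4 also isolates the change on the aromatic carbon: trifluoromethyl in place of methyl gives a 22-fold lower number from compound 1 to compound 4 (1.33 log units; beyond the scatter), so the large gap seen for compound 1 belongs to that change and not to the ring methyl. No evidence is at hand to explain either result.

Going by these compounds, whether another group on that ring carbon, such as a hydroxyl, or a morpholine in place of the piperidine, would keep the number in this range remains open. So does whether a chlorine or a methoxy group on the aromatic carbon would match trifluoromethyl or methyl.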